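Swapping the Chain End of Compound 2

A few compounds are considered here, and "the series" means these few. Any claim that something is new, unique, unknown or untested is made for them only; others in the source may bear on it.

Measured in a functional assay on HepG2 cells (Homo sapiens) for cytotoxicity, read by MTT assay; a lower number here means a stronger inhibitor, a higher number a weaker inhibitor:
- Compound 1 `Cc1c(O)cc(CCCCC(C)C)oc1=O`: > 200000 nM
- Compound 2 `Cc1c(O)cc(CCCC(C)C)oc1=O`: > 200000 nM

Both entries are limits of the assay and not numbers. Compound 2 stands at > 200000 nM, which is a limit.

Compound 3 `Cc1c(O)cc(CCCCC(C)(C)O)oc1=O` has 2-hydroxy-2-methylpropyl in place of isopropyl on a saturated chain carbon, three bonds along the chain from an aromatic carbon.

Within the data shown here, only one measured step bears on this change, since it falls at the same place on the chain: a step that the two limits leave unreadable from compound 1 to compound 2. The data offer just (the limit of > 200000 nM in this assay, at which 2 of the 2 values shown sit), so no size can be taken from that step. No step beyond the scatter is therefore expected in this assay, and no direction can be favoured. Another limit is the most likely outcome.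

The expected step is a step that the limit leaves unreadable from compound 2 to compound 3. For compound 3 the estimated value is 220000 nM. The expected range for compound 3 runs from 100000 nM to 400000 nM.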

Compound 3, half-maximal inhibitory concentration: > 200000 nM
Compound 3: only a limit was reported; the forecaster's own chance of this, stated with the estimate: 80%; the middle value is on the limit's open side.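

Compound 3 gives > 200000 nM in this assay and this is a limit, not a number. No step among compound 1, compound 2 and compound 3 can be read, as all three entries are limits: the limit of > 200000 nM in this assay, at which 3 of the 3 values shown sit.

On these data alone, how these chain ends would rank against one another in this assay stays open.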